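Bromo in place of hydrogen on compound 2

The source may hold more compounds than are shown below. What is called first, only, known or untested is meant among the compounds shown, and "the series" means these compounds.

compound 1 `Cc1ccc([N+](=O)[O-])cc1S(=O)(=O)N(C)/N=C/c1onc2ccccc12`: 3900 nM
compound 2 `Cc1ccc([N+](=O)[O-])cc1S(=O)(=O)N(C)/N=C/c1cncc2ccccc12`: 890 nM

In a functional assay on NZB5 cells (Homo sapiens) for antiproliferative activity (a higher number here means a weaker inhibitor, a lower number a stronger inhibitor), compound 2 gives 890 nM, the lower of the two numbers. Compound 1 gives 3900 nM, and the gap between them lies beyond the scatter.

Compound 3 `Cc1ccc([N+](=O)[O-])cc1S(=O)(=O)N(C)/N=C/c1cncc2c(Br)cccc12` has not yet been measured. It differs from compound 2 in one place: bromo in place of hydrogen on an aromatic carbon, with bromo in place of hydrogen on an aromatic carbon. Among the measured compounds shown here, the series holds no measured step for a change of this kind, so the expectation rests on compound 2 at 890 nM alone. No step beyond the scatter is expected in this assay, and the estimated step is a 1.3-fold lower number from compound 2 to compound 3 (0.10 log units; within the scatter). The wide range reflects how little the data show.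

For compound 3 the estimated value is 700 nM, with an expected range from 200 nM to 2500 nM.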

Compound 3, half-maximal inhibitory concentration: 5700 nM
For compound 3 the middle estimate is 8.1-fold (0.91 log units) below the measured one; measured number outside the range, above it.
By their numbers in this assay, from the lowest: compound 2; then compounds 1 and 3 (each within the scatter of the next).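

In this assay, bromo in place of hydrogen gives a clear loss of activity (a 6.4-fold higher number from compound 2 to compound 3 (0.81 log units; beyond the scatter)). Among the compounds shown here, this is the first measured single-place step, and it shows that this aromatic carbon, on the six-membered aromatic ring of carbon only within the fused system, is sensitive to substitution: with these two compounds, hydrogen is the better of the two groups there. Nothing measured here accounts for the loss.

The compounds shown leave open whether the step belongs to bromo alone or to any group on this carbon, as fluoro, methyl, methoxy or an amine would show. Also open, going by these compounds, is whether bromo on the other carbons of the same ring brings a similar loss.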